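The source may report more compounds than this note shows. Statements on the series, on what has been measured and on what is new or still open speak of the compounds shown alone.

Three related compounds have been tested in an assay on isolated protein for inhibition of Equilibrative nucleoside transporter 1 (Homo sapiens); on this read-out higher numbers stand for weaker inhibition and lower numbers for stronger inhibition. Compound 1 `OC[C@H]1O[C@@H](n2cnc3c(SCc4ccc(Br)cc4)ncnc32)[C@H](O)[C@@H]1O` gives 11.5 nM, compound 2 `OC[C@H]1O[C@@H](n2cnc3c(SCc4ccccc4I)ncnc32)[C@H](O)[C@@H]1O` gives 19.5 nM, and compound 3 `N#Cc1cccc(CSc2ncnc3c2ncn3[C@@H]2O[C@H](CO)[C@@H](O)[C@H]2O)c1` gives 36.3 nM. All three share the same core; they differ only in the aromatic group carried on a saturated chain carbon bound to a sulfur. Among the three, compound 2 stands with the second highest number, closest to compound 1 and furthest from compound 3, and both of those gaps stay within the usual scatter.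

Compound 4 `CC(C)(C)c1ccc(CSc2ncnc3c2ncn3[C@@H]2O[C@H](CO)[C@@H](O)[C@H]2O)cc1` has not yet been measured. Its relationship to compound 2 is this: 4-(tert-butyl)phenyl in place of 2-iodophenyl on a saturated chain carbon bound to a sulfur.

The measured steps speak to swapping one substituted phenyl for another at this position. The change a 1.7-fold higher number from compound 1 to compound 2 (0.23 log units; within the scatter) and the change a 1.9-fold higher number from compound 2 to compound 3 (0.27 log units; within the scatter) both stay within the scatter, while a 3.2-fold higher number from compound 1 to compound 3 (0.50 log units; beyond the scatter) reaches a modest size. A new substituted phenyl is therefore expected to shift this assay only slightly, with no clear direction beyond the scatter.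

For compound 4 the expected value is 16 nM, with a range from 5 nM to 50 nM. This estimate corresponds to an expected step of a 1.2-fold lower number from compound 2 to compound 4 (0.09 log units; within the scatter).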

Compound 4, inhibition constant: 10000 nM
Beside the measured number, compound 4's estimate is 630-fold (2.80 log units) below it, outside the stated range (above it).
By their numbers in this assay, from the lowest: compounds 1, 2 and 3 (each within the scatter of the next, the first and the last beyond it); then compound 4.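

At this place, on a saturated chain carbon bound to a sulfur, swaps among the earlier substituted phenyl groups had moved this assay only a little, but 4-(tert-butyl)phenyl gives a 510-fold higher number from compound 2 to compound 4 (2.71 log units; beyond the scatter) and a 280-fold higher number from compound 3 to compound 4 (2.44 log units; beyond the scatter) as well. The cleanest comparison keeps everything else fixed: tert-butyl in place of bromo on an aromatic carbon gives an 870-fold higher number from compound 1 to compound 4 (2.94 log units; beyond the scatter) and so ties the weaker inhibition to that one group. The position therefore does not accept every substituted phenyl equally, and a single change of group can separate compound 4 from the other three by far more than those three differ among themselves.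

The compounds shown leave open whether a methyl or an isopropyl group on that same aromatic carbon would stay close to compound 1 or fall towards compound 4, which would show whether the sharp drop belongs to tert-butyl alone. Nothing measured here explains why this group behaves so differently from the other three.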